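A few compounds are considered here, and "the series" means these few. Any claim that something is new, unique, unknown or untested is made for them only; others in the source may bear on it.

The three measured compounds are compound 1 `Cc1ccc2nc(/N=C3\C(=O)N(CN(c4ccccc4)c4ccccc4)c4ccccc43)sc2c1`, compound 2 `Cc1ccc2nc(/N=C3\C(=O)N(CN4CCCCC4)c4cccc(Br)c43)sc2c1` and compound 3 `CCN(CC)CN1C(=O)C(=O)c2c(Cl)cccc21`. In a functional assay on MCF7 cells (Homo sapiens) for cytotoxicity, read by sulforhodamine B assay, with a stated time of 48 h (a higher number here means a weaker inhibitor of growth, a lower number a stronger inhibitor of growth), compound 1 gives 39200 nM, compound 2 gives 39100 nM and compound 3 gives 34100 nM. Compound 2 stands second highest of the three numbers, but its nearest neighbour, compound 1, lies within the scatter of it, and so does the furthest, compound 3, so nothing separates these three in this assay.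

Compound 4 `Cc1ccc2nc(/N=C3\C(=O)N(CN4CCCCC4)c4cccc(Cl)c43)sc2c1` is not yet measured. It differs from compound 2 by chloro in place of bromo on an aromatic carbon. Among the measured compounds shown here, no step between measured compounds is known for any change of this kind, so the expectation rests only on the values of compound 2 and its neighbours, which all sit close together. The step from a 1.0-fold lower number from compound 2 to compound 4 (0.00 log units; within the scatter) is expected to stay within the scatter, with no clear direction. Compound 4 is therefore estimated at 39000 nM in this assay, within a range of 15000 nM to 100000 nM.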

Compound 4, concentration for 50% growth inhibition: 30900 nM
Compound 4: middle estimate off by 1.3-fold (0.10 log units), on the high side; the measured number falls inside the stated range.
By their numbers in this assay, from the lowest: compounds 4, 3, 2 and 1 (each within the scatter of the next).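

In this assay, chloro in place of bromo on this aromatic carbon, ortho to a fused ring and meta to a fused ring, gives a 1.3-fold lower number from compound 2 to compound 4 (0.10 log units; within the scatter). Among the compounds shown here, this is the first step that can be read at this position, and it shows that, with the rest of the molecule unchanged, one of these halogens can replace the other here without the number leaving the scatter. Nothing available bears on why this exchange gives so small a step.

The compounds shown compare only these two halogens at this position, so it remains open whether an amine, a methoxy group or a carboxylic acid there would give a step beyond the scatter. Also open, on these data alone, is whether the same exchange would give a similar step with a different group elsewhere on the shared core.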